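This account rests on a few compounds, and the source may have more. Where it says the series, first, only, none or still open, it means among the compounds named here.

Compound 1 `COc1cc(-c2nn(-c3cccc(NC(=O)c4cccc(C(F)(F)F)c4)c3)cc2-c2ccncc2)ccc1Cl` stands in a functional assay on OVCAR-8 cells (Homo sapiens) for inhibition, read by sulforhodamine B assay, with a stated time of 48 h (on this read-out lower numbers stand for stronger inhibition of growth and higher numbers for weaker inhibition of growth), at > 50000 nM, which is a limit of the assay and not a number. Compound 2 `COc1cc(-c2nn(-c3cccc(NC(=O)Nc4cccc(C(F)(F)F)c4)c3)cc2-c2ccncc2)ccc1Cl` gives 2700 nM in this assay. Compound 3 `O=C(Nc1cccc(-n2cc(-c3ccncc3)c(-c3ccc(Cl)c(O)c3)n2)c1)Nc1cc(C(F)(F)F)cc(C(F)(F)F)c1` gives 5920 nM in this assay.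

Compound 1 thus sits at the limit of > 50000 nM in this assay, at which 1 of the 3 values shown sits; on the numbers shown it stands at the weak end and has no number of its own. Compound 4 `COc1cc(-c2nn(-c3cccc(NC(=O)Nc4ccc(Cl)c(C(F)(F)F)c4)c3)cc2-c2ccncc2)ccc1Cl` has not yet been measured. It differs from compound 1 in one place: (4-chloro-3-(trifluoromethyl)phenyl)amino in place of 3-(trifluoromethyl)phenyl on a carbonyl carbon. Among the compounds with values here, the one measured step that bears on this is the step from compound 1 to compound 2, where the carbonyl carbon likewise received an amino-linked ring in place of the directly bound ring, a change that produced an at least 18-fold lower number from compound 1 to compound 2 (1.26 log units; beyond the scatter). Compound 3 carries a related amino-linked ring on the carbonyl carbon, with a different ring and a different group on the shared core, and also reaches a measurable number in this assay. Compound 4 is therefore expected to show a large step in this assay toward a lower number, an at least 20-fold lower number from compound 1 to compound 4 (1.30 log units; beyond the scatter), of a size close to that seen for compound 2. The estimate for compound 4 is 2500 nM, with a range from 600 nM to 10000 nM.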

Compound 4, concentration for total growth inhibition: 5870 nM
For compound 4 the middle estimate is 2.3-fold (0.37 log units) below the measured one; the range from low to high includes it.
By their numbers in this assay, from the lowest: compound 2; then compounds 4 and 3 (each within the scatter of the next). At a limit, above all of these: compound 1.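

In this assay, the gain from replacing the 3-(trifluoromethyl)phenyl on the carbonyl carbon with an amino-linked ring now holds for a second ring, since (4-chloro-3-(trifluoromethyl)phenyl)amino in that place gives an at least 8.5-fold lower number from compound 1 to compound 4 (0.93 log units; beyond the scatter). Chloro in place of hydrogen on an aromatic carbon, the one difference between the two amino-linked compounds, gives a 2.2-fold higher number from compound 2 to compound 4 (0.34 log units; beyond the scatter), so in this pair the added chloro does not extend the gain but gives back a modest part of it. Compound 1 stands at a limit and not at a number, so the full size of the step from it stays unknown: the limit of > 50000 nM in this assay, at which 1 of the 4 values shown sits.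

The compounds shown leave open whether a fluoro, a methyl or a methoxy group in place of this chloro would give the same modest step, or whether that step is particular to chloro. They also leave open whether a methylamino link on the carbonyl carbon, in place of the amino link, would keep the gain seen for compound 2 and compound 4.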